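The source may report more compounds than this note shows. Statements on the series, on what has been measured and on what is new or still open speak of the compounds shown alone.

Working notes on the series. The shared core of compound 1 `COc1cccc(OC)c1OCCNCCOc1ccccc1OCc1cccc(C)c1` carries a varied aryl group on the saturated chain carbon bound to an oxygen on an aromatic ring. In an assay on CHO cells for displacement of a labelled ligand from Alpha-1D adrenergic receptor (Homo sapiens) (a lower number here means a stronger inhibitor, a higher number a weaker inhibitor), compound 1 gives 0.2 nM. Compound 2 `COc1cccc(OC)c1OCCNCCOc1ccccc1OCc1ccc(C)cc1` gives 0.0631 nM in this assay, and compound 3 `COc1cccc(OC)c1OCCNCCOc1ccccc1OCc1ccccc1[N+](=O)[O-]` gives 0.912 nM in this assay. Compound 3 thus stands highest of the three numbers, with a 4.6-fold higher number from compound 1 to compound 3 (0.66 log units; beyond the scatter) and a 14-fold higher number from compound 2 to compound 3 (1.16 log units; beyond the scatter). Between the two methylphenyl compounds the gap is smaller, a 3.2-fold lower number from compound 1 to compound 2 (0.50 log units; beyond the scatter).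

Compound 4 `COc1cccc(COc2ccccc2OCCNCCOc2c(OC)cccc2OC)c1` differs from compound 3 in one place: 3-methoxyphenyl in place of 2-nitrophenyl on a saturated chain carbon bound to an oxygen on an aromatic ring. Among the measured compounds shown here, no measured step sets a methoxy against a methyl on this carbon. For the measured compounds named here, the steps that bear on the change are the two that remove the 2-nitrophenyl, both beyond the scatter and both toward lower numbers. Compound 1, with its 3-methylphenyl, gives 0.2 nM in this assay, and a 3-methoxyphenyl is the nearest comparison among the measured groups. A modest step toward a lower number is therefore expected in this assay, about a 4.6-fold lower number from compound 3 to compound 4 (0.66 log units; beyond the scatter). For compound 4 the estimate in this assay is 0.2 nM, in the range 0.05 nM to 0.8 nM.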

Compound 4, inhibition constant: 0.316 nM
Beside the measured number, compound 4's estimate is 1.6-fold (0.20 log units) below it; the range from low to high includes it.
By their numbers in this assay, from the lowest: compound 2; then compounds 1 and 4 (each within the scatter of the next); then compound 3.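

In this assay, 3-methoxyphenyl in place of 2-nitrophenyl on a saturated chain carbon bound to an oxygen on an aromatic ring also moves the number down (a 2.9-fold lower number from compound 3 to compound 4 (0.46 log units; beyond the scatter)), so this fall is not confined to the two methylphenyl groups. The series now has a direct comparison of methoxy with methyl on an aromatic carbon (a 1.6-fold higher number from compound 1 to compound 4 (0.20 log units; within the scatter)), and the two cannot be separated at this resolution. The 4-methylphenyl group remains distinct from the 3-methoxyphenyl group (a 5.0-fold higher number from compound 2 to compound 4 (0.70 log units; beyond the scatter)), so compound 2 still has the lowest number of the series.

No evidence shown accounts for these differences. On these data alone, whether an amine or a carboxylic acid in place of the methoxy group would keep the number near that of compound 4 remains open.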